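Restoring the nitrogen hydrogen: compound 3 in the pyrazole series

This account rests on a few compounds, and the source may have more. Where it says the series, first, only, none or still open, it means among the compounds named here.

Measured in a functional assay on LOX IMVI cells (Homo sapiens) for inhibition, read by sulforhodamine B assay, with a stated time of 48 h; on this read-out higher numbers stand for weaker inhibition of growth and lower numbers for stronger inhibition of growth:
compound 1 `CCCCCCCCCCCC[C@@H](O)[C@H]1CC[C@H]([C@H](O)CCCCCCCCCCNC(=O)c2ccnn2C)O1`: 10 nM
compound 2 `CCCCCCCCCCCC[C@@H](O)[C@H]1CC[C@H]([C@H](O)CCCCCCCCCCN(C)C(=O)c2ccnn2C)O1`: 1410 nM

Compound 2 has the higher of the two numbers, at 1410 nM. Compound 3 `CCCCCCCCCCCC[C@@H](O)[C@H]1CC[C@H]([C@H](O)CCCCCCCCCCNCc2ccnn2C)O1` is not yet measured and differs from compound 2 as follows: ((1-methyl-1H-pyrazol-5-yl)methyl)amino in place of methyl((1-methyl-1H-pyrazol-5-yl)carbonyl)amino on a saturated chain carbon, ten or more bonds along the chain from an oxygen on a saturated carbon and a saturated ring carbon. The change is ((1-methyl-1H-pyrazol-5-yl)methyl)amino in place of methyl((1-methyl-1H-pyrazol-5-yl)carbonyl)amino, on a saturated chain carbon. For the measured compounds named here, the one measured step that bears on it is a 140-fold higher number from compound 1 to compound 2 (2.15 log units; beyond the scatter), with methyl in place of hydrogen on an amide-type nitrogen. Going by the values given here, compound 3 again has a hydrogen on that nitrogen, as does compound 1 at 10 nM, but it has no carbonyl, and no measured compound shows what that loss does. A large move to a lower number in this assay is therefore expected, though probably not the full return. The expected size is a 14-fold lower number from compound 2 to compound 3 (1.15 log units; beyond the scatter). For compound 3 the estimated value is 100 nM, with an expected range of 15 nM to 700 nM.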

Compound 3, concentration for 50% growth inhibition: 1200 nM
Beside the measured number, compound 3's estimate is 12-fold (1.08 log units) below it; measured number above the stated range.
By their numbers in this assay, from the lowest: compound 1; then compounds 3 and 2 (each within the scatter of the next).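

In this assay, the nitrogen hydrogen alone does not restore the activity of compound 1: compound 3 carries that hydrogen and compound 2 does not, yet the step is a 1.2-fold lower number from compound 2 to compound 3 (0.07 log units; within the scatter). With the hydrogen kept, (1-methyl-1H-pyrazol-5-yl)methyl in place of (1-methyl-1H-pyrazol-5-yl)carbonyl gives a 120-fold higher number from compound 1 to compound 3 (2.08 log units; beyond the scatter), so losing the carbonyl is a large step here, as losing the amide hydrogen was in a 140-fold higher number from compound 1 to compound 2 (2.15 log units; beyond the scatter), and of these three only compound 1, which has both, gives 10 nM. No measurement shown offers a reason for either large step.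

Open, on these data alone, is whether the carbonyl itself is needed or another linkage that keeps the nitrogen hydrogen would serve, such as a urea or a sulfonamide. Also open, as far as these compounds go, is how much the 1-methyl-1H-pyrazol-5-yl group contributes, which an amide carrying a phenyl group would test.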